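Piperazine amide series: benzyl in place of methyl

The compounds below may be only part of what the source reports. "The series", "measured", "known", "first", "only" and "open" are said of these compounds alone.

Compound 1 `Cn1c(-c2ccc(NC(=O)CSc3nc4ccccc4o3)cc2)nc(-c2ccccc2)c1-c1ccccc1` gives 42.3% in a functional assay on MCF7 cells (Homo sapiens) for cytotoxicity, read by MTT assay, with a stated time of 24 h, tested at 6.4 ug/mL (on this read-out higher numbers stand for a stronger effect at the one concentration tested and lower numbers for a weaker effect), compound 2 `Cn1nnnc1SCC(=O)Nc1ccc(-c2nc(-c3ccccc3)c(-c3ccccc3)n2C)cc1` gives 55.9%, and compound 3 `CCN1CCN(CC(=O)Nc2ccc(-c3nc(-c4ccccc4)c(-c4ccccc4)n3C)cc2)CC1` gives 16.4%, the lowest of the three numbers. The steps measured so far, a number 13.6 percentage points higher from compound 1 to compound 2 (beyond the scatter), a number 25.9 percentage points lower from compound 1 to compound 3 (beyond the scatter) and a number 39.5 percentage points lower from compound 2 to compound 3 (beyond the scatter), all exchange the group on the saturated chain carbon bound to the carbonyl carbon. Compound 4 `Cc1ccc(CN2CCN(CC(=O)Nc3ccc(-c4nc(-c5ccccc5)c(-c5ccccc5)n4C)cc3)CC2)cc1` differs from compound 3 elsewhere: 4-methylphenyl in place of methyl on a saturated chain carbon bound to an amine nitrogen in a ring. No measured step touches this position, so nothing shown bears on it directly, and a step within the scatter is the plainest expectation. Compound 4 is therefore estimated at 22%, with a range from 8% to 42%. The expected step is a number 5.6 percentage points higher from compound 3 to compound 4 (within the scatter).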

Compound 4, a percentage reported as activity, at one concentration (the size of the read-out at that concentration, not a potency): 21.8%
Compound 4: the middle estimate sits 0.2 percentage points above what was measured; measured number inside the range.
By their numbers in this assay, from the lowest: compounds 3 and 4 (each within the scatter of the next); then compound 1; then compound 2.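

In this assay, 4-methylphenyl in place of methyl on a saturated chain carbon bound to an amine nitrogen in a ring gives a number 5.4 percentage points higher from compound 3 to compound 4 (within the scatter). This position therefore accepts a group of 7 heavy atoms with an aromatic ring, in place of a single carbon, with no step beyond the scatter. Nothing available bears on the reason for this outcome. Still open, on these data alone, is whether a carboxylic acid in place of the methyl on the 4-methylphenyl group, or a longer chain carrying that ring, would shift the read-out beyond the scatter.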